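The compounds below may be only part of what the source reports. "The series", "measured", "known", "first", "only" and "open" are said of these compounds alone.

Measured in an ADME assay on microsomes from liver (Mus musculus) for metabolic stability, read by LC-MS, using NADPH, with stated times of 15 min and 60 min, tested at 4.6 uM; a lower number here means that the compound disappears faster, a higher number that the compound lasts longer:
Compound 1 `CN1CCN(c2ccc3c(c2)oc(=O)n3C(=O)NCCCCc2ccccc2)C(=O)C1`: < 0.0834 h
Compound 2 `CN1CCN(c2ccc3c(c2)oc(=O)n3C(=O)NCCCCc2ccccc2)CC1=O`: 0.5 h

The entry for compound 1 is a limit and not a number, as the limit of < 0.0834 h in this assay, at which 1 of the 2 values shown sits, records. Among the compounds with values here, compound 2 therefore holds the only true number in this assay, 0.5 h. Within the data shown here, the one measured step is an at least 5.9-fold higher number from compound 1 to compound 2 (0.77 log units; beyond the scatter), with 4-methyl-3-oxopiperazin-1-yl in place of 4-methyl-2-oxopiperazin-1-yl on an aromatic carbon.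

Compound 3 `CCN1CCC(c2ccc3c(c2)oc(=O)n3C(=O)NCCCCc2ccccc2)CC1` carries 1-ethylpiperidin-4-yl in place of 4-methyl-3-oxopiperazin-1-yl on the same aromatic carbon (1-ethylpiperidin-4-yl in place of 4-methyl-3-oxopiperazin-1-yl on an aromatic carbon). The measured step bears on this only indirectly, since it links two oxopiperazinyl groups, but an at least 5.9-fold higher number from compound 1 to compound 2 (0.77 log units; beyond the scatter) shows that a change at this place can go beyond the scatter. A moderate fall in this assay is expected, with an estimated step of a 2.5-fold lower number from compound 2 to compound 3 (0.40 log units; beyond the scatter). Compound 3 is expected at 0.2 h, within an estimated range of 0.08 h to 0.6 h.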

Compound 3, half-life: 1 h
Beside the measured number, compound 3's estimate is 5.0-fold (0.70 log units) below it, and the stated range ends below it.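

With 1-ethylpiperidin-4-yl on the aromatic carbon, a group with one hetero atom in its ring and no double bond outside aromatic rings, this assay gives a 2.0-fold higher number from compound 2 to compound 3 (0.30 log units; within the scatter), so this change cannot be told apart from no change. Set against 4-methyl-2-oxopiperazin-1-yl, the same group gives an at least 11-fold higher number from compound 1 to compound 3 (1.07 log units; beyond the scatter), which means that among the three groups shown, only 4-methyl-2-oxopiperazin-1-yl stands apart. The entry for compound 1 is a limit and not a number: the limit of < 0.0834 h in this assay, at which 1 of the 3 values shown sits.

From the compounds shown here alone, it remains open whether a methyl group in place of the ethyl on the piperidine nitrogen would leave the half-life within the scatter. The same is open for a morpholine ring or a carboxylic acid on this aromatic carbon.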